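This account rests on a few compounds, and the source may have more. Where it says the series, first, only, none or still open, it means among the compounds named here.

In an ADME assay on L02 cells (Homo sapiens) for cytotoxicity, read by MTT assay, with a stated time of 24 h (a higher number here means a weaker inhibitor, a lower number a stronger inhibitor), compound 3 `Cc1ccc(S(=O)(=O)N2C/C(=C\c3cccnc3)C(=O)/C(=C/c3ccccc3C(F)(F)F)C2)cc1` gives 12300 nM and compound 2 `O=C1/C(=C/c2cccnc2)CN(S(=O)(=O)c2ccccc2)C/C1=C\c1ccccc1C(F)(F)F` gives 12500 nM. These two sit level, and the only other result is a limit. Compound 1 `O=C1/C(=C/c2cccnc2)CN(S(=O)(=O)c2ccc([N+](=O)[O-])cc2)C/C1=C\c1ccccc1F`, which also carries the (4-nitrophenyl)sulfonyl group, reads > 20000 nM, and this is a limit of the assay, not a number.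

Compound 4 `O=C1/C(=C/c2cccnc2)CN(S(=O)(=O)c2ccc([N+](=O)[O-])cc2)C/C1=C\c1ccccc1C(F)(F)F` has nitro in place of methyl on an aromatic carbon, para to a large group, relative to compound 3: nitro in place of methyl on an aromatic carbon. Among the compounds with values here, the one measured step at this carbon is a 1.0-fold lower number from compound 2 to compound 3 (0.01 log units; within the scatter), where methyl replaced hydrogen. Within the data shown here, no measured step isolates nitro in place of methyl, so that small step is only indirect support, and no change beyond the scatter is expected in this assay. The limit of the series, (the limit of > 20000 nM in this assay, at which 1 of the 3 values shown sits), could also apply to compound 4, so a limit reading remains possible.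

The expected step is a 1.1-fold higher number from compound 3 to compound 4 (0.06 log units; within the scatter).

For compound 4 the estimated value is 14000 nM, with an expected range of 6500 nM to 30000 nM.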

Compound 4, half-maximal inhibitory concentration: 15700 nM
Compound 4: the middle estimate sits 1.1-fold (0.05 log units) below what was measured, and the stated range covers the measured number.
By their numbers in this assay, from the lowest: compounds 3, 2 and 4 (each within the scatter of the next). At a limit, above all of these: compound 1.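

In this assay, the aromatic carbon para to a large group now carries hydrogen, methyl or nitro, and nitro also stays within the scatter of the other two: a 1.3-fold higher number from compound 3 to compound 4 (0.11 log units; within the scatter), and a 1.3-fold higher number from compound 2 to compound 4 (0.10 log units; within the scatter). The (4-nitrophenyl)sulfonyl group therefore does not by itself bring a limit reading, as compound 1 alone might have suggested, and an at least 1.2-fold lower number from compound 1 to compound 4 (0.10 log units; that floor lies within the scatter), with trifluoromethyl in place of fluoro, gives only a floor on that step. Within the data shown here, compound 1 remains the only limit reading: the limit of > 20000 nM in this assay, at which 1 of the 4 values shown sits.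

On these data alone, whether an amine or a carboxylic acid on this carbon would move the number beyond the scatter remains open. The true size of the step from fluoro to trifluoromethyl also stays unresolved, since one end of it is a limit.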